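Methyl in place of fluoro on the aryl of compound 3

This account rests on a few compounds, and the source may have more. Where it says the series, first, only, none or still open, it means among the compounds named here.

Of the compounds shown here, three have numbers so far. In a functional assay, read by spectrophotometry, with a stated time of 15 min, tested at 40 ug/mL (a higher number here means a stronger effect of the compound at the concentration tested, a lower number a weaker effect), compound 1 `Clc1ccc(-c2csc(N/N=C/c3cccs3)n2)cc1` gives 96%. Compound 2 `Cc1ccc(-c2csc(N/N=C/c3ccc(Cl)cc3Cl)n2)cc1`, which carries a methyl on the aryl together with a different hydrazone partner, gives 86.2% in this assay. Compound 3 `Fc1ccc(-c2csc(N/N=C/c3cccs3)n2)cc1` gives 93.3% in this assay. On these numbers compound 3 sits nearest compound 1 and furthest from compound 2, and both gaps are within the scatter, so no order among the three can be read.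

Compound 4 `Cc1ccc(-c2csc(N/N=C/c3cccs3)n2)cc1` differs from compound 3 in one place: methyl in place of fluoro on an aromatic carbon. Within the data shown here, the only measured step at that position is a number 2.7 percentage points lower from compound 1 to compound 3 (within the scatter), a change of the halogen that left the number where it was. Among the measured compounds shown here, no measured step swaps fluoro for methyl; compound 2 has a methyl at the same place but differs in the hydrazone part as well, so its number only shows that a methyl-bearing aryl is compatible with a high read-out in this assay. No step beyond the scatter is therefore expected in this assay.

Compound 4 is estimated at 91%, with a range of 80% to 98%. The expected step is a number 2.3 percentage points lower from compound 3 to compound 4 (within the scatter), within the scatter.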

Compound 4, a percentage reported as inhibition, at one concentration (the size of the read-out at that concentration, not a potency): 97%
Compound 4: the middle estimate sits 6 percentage points below what was measured, within the range that was stated.
By their numbers in this assay, from the lowest: compounds 2, 3, 1 and 4 (each within the scatter of the next, the first and the last beyond it).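

Compound 4 gives this position its first direct test of a non-halogen group with the thiophene-free wording set aside: on an aromatic carbon para to a large group, with everything else in the core and hydrazone part held constant, methyl can now be compared with both fluoro and chloro in this assay. Methyl in place of fluoro gives a number 3.7 percentage points higher from compound 3 to compound 4 (within the scatter) and methyl in place of chloro gives a number 1 percentage points higher from compound 1 to compound 4 (within the scatter) so neither change moves the read-out beyond the usual scatter, and the three groups cannot be ordered at this place. Nothing measured accounts for this tolerance or connects it to any property of the groups.

Going by these compounds, whether the read-out holds with a group of another kind at this place, such as an amine, a carboxylic acid or a longer chain, remains open. Since this assay reports one tested concentration, it also leaves open whether compound 1, compound 3 and compound 4 would remain indistinguishable in the size of their effect at other concentrations.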